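The source may hold more compounds than are shown below. What is called first, only, known or untested is meant among the compounds shown, and "the series" means these compounds.

Of the compounds shown here, three share one core and have been tested in a functional assay on HCT-116 cells (Homo sapiens) for antiproliferative activity, read by MTT assay, with a stated time of 48 h; on this read-out lower numbers stand for stronger inhibition and higher numbers for weaker inhibition: compound 1 `Cc1ccc2nc(Nc3nc(Nc4ccc(S(N)(=O)=O)cc4)ncc3F)sc2c1`, compound 2 `Cc1cnc(Nc2ccc(C(C)C)cc2)nc1Nc1nc2ccccc2s1` and compound 3 `CS(=O)(=O)c1ccc(Nc2ncc(F)c(Nc3nc4ccc(F)cc4s3)n2)cc1`. In this assay, among the compounds with values here, compound 1 gives 1460 nM, the only plain number among the three. Compound 2 returns only a limit in this assay, > 50000 nM. Compound 3 also returns only a limit, > 50000 nM. Compound 2 therefore stands at the limit of > 50000 nM in this assay, at which 2 of the 3 values shown sit, with no number of its own to compare against.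

The next compound, compound 4 `Cc1cnc(Nc2ccc(F)cc2)nc1Nc1nc2ccccc2s1`, differs from compound 2 by fluoro in place of isopropyl on an aromatic carbon. Within the data shown here, no pair of measured compounds shows this change, so there is no measured step to lean on. With compound 2 at the limit, only a move toward a measurable value would be visible at all, and the record gives no ground to expect one beyond the scatter. The estimated step from compound 2 to compound 4 in this assay is a number no higher from compound 2 to compound 4 (the limit leaves the size open). Compound 4 is expected at about 50000 nM, between 10000 nM and 200000 nM.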

Compound 4, half-maximal inhibitory concentration: > 50000 nM
Compound 4 ended at the assay's limit (the forecaster's own chance of this, stated with the estimate: 60%); the middle value sits exactly at the limit.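

Compound 2 and compound 4 both end at a limit in this assay, so no step can be read between them: the limit of > 50000 nM in this assay, at which 3 of the 4 values shown sit.

The compounds shown leave open whether 4-isopropylphenyl and 4-fluorophenyl differ at all in this assay, and what sets compound 1, the only plain number, apart from the other three.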